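A few compounds are considered here, and "the series" means these few. Any claim that something is new, unique, unknown or untested is made for them only; others in the source may bear on it.

Of the compounds shown here, three share the same sulfone-linked arrangement and have been tested in an ADME assay on microsomes from liver (Homo sapiens) for metabolic stability, tested at 2.5 uM; a higher number here means faster removal of the compound, a lower number slower removal. Compound 1, `O=S(=O)(c1ccc(F)cc1)c1cnc2cc(Cl)ccc2c1-c1ccc(Cl)cc1`, gives 0.21 mL/min there. Compound 2, `O=S(=O)(c1ccc(F)cc1)c1cnc2cc(F)ccc2c1-c1ccc(Cl)cc1`, gives 1.23 mL/min in this assay. The two differ by fluoro in place of chloro on an aromatic carbon and this single change gave a 5.9-fold higher number from compound 1 to compound 2 (0.77 log units; beyond the scatter). Compound 3, `N#Cc1cccc(S(=O)(=O)c2cnc3c(F)cccc3c2-c2ccc(Cl)cc2)c1`, gives 0.08 mL/min in this assay, the lowest of the three numbers. The difference between the core of compound 3 and the core of compound 1 is not broken down here.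

Compound 4, `N#Cc1cccc(S(=O)(=O)c2cnc3c(F)cccc3c2-c2ccc(F)cc2)c1`, has not yet been measured. It differs from compound 3 by fluoro in place of chloro on an aromatic carbon. Going by the values given here, this is the same kind of change as the one between compound 1 and compound 2, but not the same: there the exchange sat on a ring that is part of a fused system, meta to a fused ring and para to a fused ring, while here it sits on a six-membered aromatic ring of carbon only, para to a large group. Because the earlier exchange gave a 5.9-fold higher number from compound 1 to compound 2 (0.77 log units; beyond the scatter), a rise is expected for the new one too, though a smaller one, expected as a 2.5-fold higher number from compound 3 to compound 4 (0.40 log units; beyond the scatter). On that basis compound 4 is estimated at 0.2 mL/min in this assay, with a likely range from 0.08 mL/min to 0.5 mL/min.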

Compound 4, intrinsic clearance in a liver preparation (reported as CLH), per the amount of preparation that the assay uses: 0.19 mL/min
Beside the measured number, compound 4's estimate is 1.1-fold (0.02 log units) above it, and the stated range covers the measured number.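

In this assay, going from 4-chlorophenyl to 4-fluorophenyl gave a 2.4-fold higher number from compound 3 to compound 4 (0.38 log units; beyond the scatter). Set beside the earlier exchange of chloro for fluoro, the new step points the same way, and the two sizes cannot be told apart: the same change on two cores in this assay, a 5.9-fold higher number (0.77 log units; beyond the scatter) from compound 1 to compound 2 and a 2.4-fold higher number (0.38 log units; beyond the scatter) from compound 3 to compound 4, 2.5-fold (0.39 log units) apart, within the scatter of two such steps. This shows that the change raised the number on both cores, at two different places on the molecule, but two pairs cannot show that the same rise would appear on every core in this series, nor do they explain why the number goes up.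

The compounds shown leave open whether a methoxy or trifluoromethyl group at the same place on the six-membered aromatic ring would give a similar rise, or whether the rise is particular to fluoro. They also leave open how the exchange would behave on a core carrying an amine or a carboxylic acid in place of the nitrile.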